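A few compounds are considered here, and "the series" means these few. Any claim that something is new, unique, unknown or untested is made for them only; others in the source may bear on it.

The measured compounds:
Compound 1, `Oc1ccccc1CNc1ccc(-c2cccc(F)c2)cc1`: 2020 nM
Compound 2, `Oc1ccccc1CNc1ccc(-c2cccc(Cl)c2)cc1`: 6200 nM
Compound 3, `Oc1ccccc1CNc1ccc(-c2ccccc2F)cc1`: 2150 nM

All three were tested in a functional assay on Jurkat cells (Homo sapiens) for activation, with a stated time of 24 h; a lower number here means that less compound is needed, a higher number that more compound is needed for the effect. Compound 1 and compound 3 have the same atoms, joined differently: the difference is 2-fluorophenyl in place of 3-fluorophenyl on an aromatic carbon, and the step of a 1.1-fold higher number from compound 1 to compound 3 (0.03 log units; within the scatter), so the two give the same result within the usual scatter. Compound 2 carries the change chloro in place of fluoro on an aromatic carbon relative to compound 1, and this gave a 3.1-fold higher number from compound 1 to compound 2 (0.49 log units; beyond the scatter).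

Compound 4, `Oc1ccccc1CNc1ccc(-c2ccccc2Cl)cc1`, has not yet been measured. It differs from compound 3 by chloro in place of fluoro on an aromatic carbon. Going by the values given here, this is the same kind of change as the one from compound 1 to compound 2, but not the same: there the change sits meta to a large group, here it sits ortho to a large group. Compound 4 is expected to show a 2.6-fold higher number from compound 3 to compound 4 (0.41 log units; beyond the scatter) in this assay. That expectation rests on the earlier step of a 3.1-fold higher number from compound 1 to compound 2 (0.49 log units; beyond the scatter), with wide uncertainty since the surroundings of the change differ. The estimate for compound 4 is 5500 nM, between 2000 nM and 15000 nM.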

Compound 4, half-maximal effective concentration: "not active" (no number reported)
The entry for compound 4 holds no number; there is nothing to compare the estimate with.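

Going by these compounds alone, compound 4 is reported as "not active" with no number, so no step from compound 3 to compound 4, or from any other compound, can be read. No supporting data shown here bear on this result. The compounds shown leave open how large the change from 2-fluorophenyl to 2-chlorophenyl is in this position.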